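The compounds below may be only part of what the source reports. "The series", "measured", "known", "first", "only" and "open" are said of these compounds alone.

Compound 3 `N=C(S)Cn1nc(-c2ccccc2)ccc1=O` sits at the bottom of the three numbers in a functional assay on the whole organism (stomach) for inhibition, with Rattus norvegicus as the target, at a dose of 100 mg/kg by the intraduodenal route (a higher number here means more inhibition at the dose given (going by the name of the read-out), a lower number less inhibition), giving 5.5%; compound 1 `N#CCCn1nc(-c2ccccc2)ccc1=O` gives 10.1%, a value within the usual scatter of compound 3, while compound 2 `N=C(S)CCCCCn1nc(-c2ccccc2)ccc1=O` gives 91.4%, far above both. Compound 4 `CN(C)C(=S)CCn1nc(-c2ccccc2)ccc1=O` has not been measured; against compound 3 it carries a group of 6 heavy atoms (4 carbon, 1 nitrogen, 1 sulfur; no ring) in place of a group of 3 heavy atoms (1 carbon, 1 nitrogen, 1 sulfur; no ring), on a saturated chain carbon bound to an aromatic nitrogen. Within the data shown here, two measured steps bear on such a change in group size on a saturated chain carbon bound to an aromatic nitrogen: a number 81.3 percentage points higher from compound 1 to compound 2 (beyond the scatter) and a number 85.9 percentage points lower from compound 2 to compound 3 (beyond the scatter). Compound 4 enters a larger group than compound 3 but a smaller one than compound 2, so the step to compound 4 is expected to be a rise of moderate size, a number 24.5 percentage points higher from compound 3 to compound 4 (beyond the scatter). Compound 4 is therefore estimated at 30%, between 5% and 65%.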

Compound 4, a percentage reported as inhibition, in the whole organism at one dose (the size of the read-out at that dose, not a potency): 46%
The estimate for compound 4 lay 16 percentage points below the measured number, and the stated range covers the measured number.
By their numbers in this assay, from the lowest: compounds 3 and 1 (each within the scatter of the next); then compound 4; then compound 2.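

In this assay this position gives a middle level as well as the two extremes: there is a number 40.5 percentage points higher from compound 3 to compound 4 (beyond the scatter) and a number 35.9 percentage points higher from compound 1 to compound 4 (beyond the scatter) but also a number 45.4 percentage points lower from compound 2 to compound 4 (beyond the scatter) on the other side. The group entering in compound 4 has 0 hydrogen-bond donors where the group leaving has 2, so a clear rise here does not need those donors.

Group size and donor count change together in this step, so their shares stay open, as does how an amine or a carboxylic acid would fare at this place. Nothing measured here explains these steps.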